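Changing one aryl arm on a shared inactive core

The source may report more compounds than this note shows. Statements on the series, on what has been measured and on what is new or still open speak of the compounds shown alone.

Compound 1 `c1ccc(-c2cccc3c2CCC3c2ncc[nH]2)nc1` reaches only a limit, not a number, in a functional assay on CHO cells for agonist activity at Alpha-1D adrenergic receptor (Homo sapiens), read by FLIPR and calcium flux (a lower number here means that less compound is needed, a higher number that more compound is needed for the effect), at > 10000 nM. Compound 2 `c1cncc(-c2cccc3c2CCC3c2ncc[nH]2)c1` also reaches only a limit in this assay, at > 10000 nM. The step that the two limits leave unreadable from compound 1 to compound 2 cannot be sized because both values sit at the limit of > 10000 nM in this assay, at which 2 of the 2 values shown sit. Compound 3 `CNC(=O)c1cccc2c1CCC2c1ncc[nH]1` carries methylcarbamoyl in place of pyridin-3-yl on an aromatic carbon. Among the measured compounds shown here, no measured step bears on this change, and the two limits give no direction for it. Compound 3 is therefore expected to remain at the limit, with an expected step that the limit leaves unreadable from compound 2 to compound 3 that stays unreadable. The estimate for compound 3 is 15000 nM, within 3000 nM to 80000 nM.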

Compound 3, half-maximal effective concentration: > 10000 nM
Compound 3 was reported as a limit; the forecaster's own chance of this, stated with the estimate: 80%; the middle value is on the limit's open side.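

No step can be read among compound 1, compound 2 and compound 3, because all three values are limits in this assay, not numbers: the limit of > 10000 nM in this assay, at which 3 of the 3 values shown sit. The compounds shown leave open whether any group at this place on the shared core gives a readable value.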